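The source may hold more compounds than are shown below. What is called first, only, known or untested is meant among the compounds shown, and "the series" means these compounds.

Measured so far:

- Compound 1, `COc1ccc(C2=NO[C@@H]3[C@H](CO)C[C@H](CO)[C@H]23)cc1OC`, in a functional assay on A549 cells (Homo sapiens) for cytotoxicity, read by MTT assay, with a stated time of 48 h (on this read-out lower numbers stand for stronger inhibition and higher numbers for weaker inhibition), gives > 50 ug/mL, which is a limit of the assay and not a number.
- Compound 2, `OC[C@@H]1C[C@H](CO)[C@@H]2C(c3ccc(F)cc3)=NO[C@H]12`, in this assay gives 31.1 ug/mL.

Compound 2 thus holds the only number shown in this assay; the one other entry is a limit. That entry belongs to compound 1, and it stands at the limit of > 50 ug/mL in this assay, at which 1 of the 2 values shown sits, so compound 1 is known only to be weaker than the point the assay can resolve. Among the compounds with values here, no pair of measured compounds differs in just one place, so no measured step is available to lean on.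

Compound 3, `N#Cc1ccc(C2=NO[C@@H]3[C@H](CO)C[C@H](CO)[C@H]23)cc1`, has not yet been tested in this assay. It differs from compound 2 by cyano in place of fluoro on an aromatic carbon. Without any measured step of this kind in the shared core, the expected move in this assay from compound 2 to compound 3 is small, either direction, and most likely within the usual scatter of repeated measurements. Compound 3 is therefore estimated at 35 ug/mL, in the range 15 ug/mL to 80 ug/mL, a step of a 1.1-fold higher number from compound 2 to compound 3 (0.05 log units; within the scatter) that is expected to stay close to compound 2.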

Compound 3, half-maximal inhibitory concentration: > 50 ug/mL
Compound 3: only a limit was reported; the forecaster's own chance of this, stated with the estimate: 40%; middle value at least 1.4-fold (0.15 log units) away from the limit.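

Within the data shown here, the change of cyano in place of fluoro on an aromatic carbon, para to a large group, is the first change in one place that can be read in this assay, and it amounts to an at least 1.6-fold higher number from compound 2 to compound 3 (0.20 log units; that floor lies within the scatter). For compound 3 the entry > 50 ug/mL is a limit of the assay and not a number, so only the floor of this step is known and its true size could be small or much larger. Among these compounds, what the result does show is that cyano at this place gives no sign of a lower number, and the only measured number still belongs to the fluoro compound, compound 2, at 31.1 ug/mL.

Compounds at the limit cannot be ranked against one another, and such entries now make up most of what is shown: the limit of > 50 ug/mL in this assay, at which 2 of the 3 values shown sit. Whether any group at this same place, such as an amine or a carboxylic acid, would bring a number clearly lower than that of compound 2 remains open.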